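The compounds below may be only part of what the source reports. "The series", "measured", "known", "first", "only" and "open" are said of these compounds alone.

Compound 1 `C=C1C[C@]23C[C@@]1(O)CC[C@H]2c1cc(Br)c(O)c(C)c1[C@@H]3Cn1cc(-c2ccc(OC)cc2)nn1`: > 20000 nM
Compound 2 `C=C1C(=O)[C@]23C[C@@]1(O)CC[C@H]2c1ccc(O)c(C)c1[C@@H]3Cn1cc(-c2ccc(F)cc2)nn1`: 250 nM

In a functional assay on SW480 cells (Homo sapiens) for cytotoxicity, read by MTT assay, with a stated time of 4 days (a lower number here means a stronger inhibitor, a higher number a weaker inhibitor), compound 1 gives only a limit of the assay, > 20000 nM. This places it at the limit of > 20000 nM in this assay, at which 1 of the 2 values shown sits. Differing from compound 1 in several places, compound 2 gives 250 nM in this assay. Compound 3 `C=C1C[C@]23C[C@@]1(O)CC[C@H]2c1cc(Br)c(O)c(C)c1[C@@H]3Cn1cc(-c2ccccn2)nn1` carries pyridin-2-yl in place of 4-methoxyphenyl on an aromatic carbon. Among the measured compounds shown here, with compound 1 known only as a limit, no measured step is available to size this change, and no shift beyond the scatter is expected in this assay. Compound 3 is therefore expected to give about 25000 nM, within 8000 nM to 80000 nM. The expected step that the limit leaves unreadable from compound 1 to compound 3 would most likely end again at the limit.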

Compound 3, half-maximal inhibitory concentration: > 20000 nM
Compound 3 gave a limit, no number (the forecaster's own chance of this, stated with the estimate: 70%); the middle value does not contradict the limit.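

Compound 1 and compound 3 both give only a limit in this assay, not a number, so no step between them can be read: the limit of > 20000 nM in this assay, at which 2 of the 3 values shown sit.

As far as these compounds go, whether pyridin-2-yl and 4-methoxyphenyl differ in effect on this core stays open.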